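The source may report more compounds than this note shows. Statements on the series, on what has been measured and on what is new or still open speak of the compounds shown alone.

Measured compounds in a functional assay on KYSE-450 cells (Homo sapiens) for inhibition, read by MTT assay, with a stated time of 48 h; on this read-out higher numbers stand for weaker inhibition and lower numbers for stronger inhibition:

- compound 1, `C/C=C/C(=O)N(Cc1ccc(OC)c(N)c1)c1cc(OC)c(OC)c(OC)c1`, compound 1 gives 310 nM
- compound 2, `C/C=C/C=C/C(=O)N(Cc1ccc(OC)c(O)c1)c1cc(OC)c(OC)c(OC)c1`, compound 2 gives 180 nM
- compound 3, `COc1ccc(CNc2cc(OC)c(OC)c(OC)c2)cc1F`, compound 3 gives 46200 nM

Compound 2 gives the lowest of the three numbers in this assay, but its gap to compound 1 lies within the usual scatter, so the two cannot be told apart; only compound 3 stands clearly apart, far weaker. Compound 4, `COc1ccc(CN(C(=O)C[Se]C#N)c2cc(OC)c(OC)c(OC)c2)cc1O`, has not yet been measured. It differs from compound 2 in one place: a group of 4 heavy atoms (2 carbon, 1 nitrogen, 1 selenium; no ring) in place of a group of 5 heavy atoms (5 carbon; no ring), on a carbonyl carbon. The carbonyl carbon and the amide-type nitrogen stay, so the shared core and the rest of the molecule are unchanged. Going by the values given here, no measured pair among the three compounds shows what such a swap on the carbonyl carbon does, so the direction of the step is uncertain. The expected step from compound 2 to compound 4 is estimated as a 2.5-fold higher number from compound 2 to compound 4 (0.40 log units; beyond the scatter), that is, a modest weakening with wide room on either side. Compound 4 is expected to give about 450 nM in this assay, with a range from 100 nM to 2500 nM.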

Compound 4, half-maximal inhibitory concentration: 280 nM
Compound 4: the middle estimate sits 1.6-fold (0.21 log units) above what was measured; the range from low to high includes it.
By their numbers in this assay, from the lowest: compounds 2, 4 and 1 (each within the scatter of the next); then compound 3.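

In this assay, swapping the penta-1,3-dien-1-yl group on the carbonyl carbon for the selenium-containing nitrile group gives a 1.6-fold higher number from compound 2 to compound 4 (0.19 log units; within the scatter), so the two compounds cannot be told apart. Going by these compounds alone, this is the first view of a change at this position: two very different groups, one an all-carbon chain with double bonds and the other carrying selenium and a triple bond, give numbers that this read-out does not separate. Nothing shown here explains this outcome.

The compounds shown leave open whether the selenium or the nitrile matters, as neither appears without the other here. Also open, as far as these compounds go, is what a plain acetyl group, a longer carbon chain, or a chain ending in an amine or a carboxylic acid would do on this carbonyl carbon.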